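Methylcarbamoyl in Place of Methoxy: An Unreadable Starting Point

The compounds below may be only part of what the source reports. "The series", "measured", "known", "first", "only" and "open" are said of these compounds alone.

Compound 2 `COc1cnc(C(=O)CCCCCCc2ccccc2)o1` stands at a limit in an assay on HEK-293T cells for inhibition of diacylglycerol lipase-alpha (Homo sapiens), read by colorimetric assay; a lower number here means a stronger inhibitor, a higher number a weaker inhibitor: compound 2 gives > 10000 nM, which is a limit of the assay and not a number. Compound 1 `O=C(CCCCCCc1ccccc1)c1ncc(Cl)o1` likewise gives only a limit, > 10000 nM. The step that the two limits leave unreadable from compound 1 to compound 2 therefore cannot be read, and the limit of > 10000 nM in this assay, at which 2 of the 2 values shown sit, marks where both values sit. Compound 3 `CNC(=O)c1cnc(C(=O)CCCCCCc2ccccc2)o1` differs from compound 2 by methylcarbamoyl in place of methoxy on an aromatic carbon. Among the compounds with values here, no measured step bears on this change, so no direction beyond the scatter can be expected. Compound 3 is estimated at 10000 nM, between 2000 nM and 50000 nM. The expected step is a number no higher from compound 2 to compound 3 (the limit leaves the size open).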

Compound 3, half-maximal inhibitory concentration: > 10000 nM
Compound 3: no number, only a limit; the forecaster's own chance of this, stated with the estimate: 70%; the middle value sits exactly at the limit.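

Compound 3 also gives only a limit, so no step among compound 1, compound 2 and compound 3 can be read: the limit of > 10000 nM in this assay, at which 3 of the 3 values shown sit.

The compounds shown leave open how chloro, methoxy and methylcarbamoyl on the shared core compare.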